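Furan-to-thiophene swap on the dihydropyrimidinethione series

This account rests on a few compounds, and the source may have more. Where it says the series, first, only, none or still open, it means among the compounds named here.

Measured so far:
compound 1 `CC1=C(C(=O)OCC(C)C)C(c2ccoc2)NC(=S)N1` — 12%
compound 2 `CC1=C(C(=O)OC(C)(C)C)C(c2ccoc2)NC(=S)N1` — 18%

Going by the values given here, in an assay on membranes from CHO cells for displacement of a labelled ligand from adenosine receptor A1 (Homo sapiens), read by scintillation counting, with a stated time of 60 min, tested at 1 uM (a higher number here means more inhibition at the concentration tested (going by the name of the read-out), a lower number less inhibition), compound 1 gives 12% and compound 2 gives 18%; the only step measured, a number 6 percentage points higher from compound 1 to compound 2 (within the scatter), is within the scatter, so compound 1 and compound 2 cannot be ordered against each other on this assay, and compound 1 stands level with the one other number in hand.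

Compound 3 `CC1=C(C(=O)OCC(C)C)C(c2ccsc2)NC(=S)N1` differs from compound 1 by thiophen-3-yl in place of furan-3-yl on a saturated ring carbon. Among the compounds with values here, no measured step concerns this kind of change: the step from compound 1 to compound 2 alters the ester oxygen substituent only, and it stayed within the scatter. There is thus no measured basis for expecting a shift in this assay beyond the scatter in either direction, and the level of compound 1 serves as the anchor.

Compound 3 is estimated at 15%, in the range 0% to 35%, which means an expected step of a number 3 percentage points higher from compound 1 to compound 3 (within the scatter) that stays within the scatter.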

Compound 3, a percentage reported as inhibition, at one concentration (the size of the read-out at that concentration, not a potency): 8%
Compound 3: the middle estimate sits 7 percentage points above what was measured; low and high end bracket the measured number.
By their numbers in this assay, from the lowest: compounds 3, 1 and 2 (each within the scatter of the next).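

In this assay, thiophen-3-yl in place of furan-3-yl on a saturated ring carbon gives a number 4 percentage points lower from compound 1 to compound 3 (within the scatter), so compound 1 and compound 3 cannot be ordered against each other. Going by these compounds alone, this is the first measured step at this position, and exchanging the ring oxygen for sulfur, with the isobutyl ester and the rest of the core held constant, produces no change that can be told from the scatter. No measured information bears on the reason for this result.

The compounds shown leave open whether a group of a different kind at this position, such as a phenyl ring, a pyridine ring or a chain carrying an amine, would move the inhibition beyond the scatter. They also leave open how thiophen-3-yl behaves alongside the tert-butyl ester.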